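Dropping the N-substituent of a trimethoxybenzyl purine

A few compounds are considered here, and "the series" means these few. Any claim that something is new, unique, unknown or untested is made for them only; others in the source may bear on it.

Compounds measured in a functional assay on MCF7 cells (Homo sapiens) for antiproliferative activity; a higher number here means a weaker inhibitor, a lower number a stronger inhibitor:
- compound 1 `CC/C=C\Cn1c(Cc2cc(OC)c(OC)c(OC)c2)nc2c(N)ncnc21` gives 64600 nM
- compound 2 `COc1cc(Cc2nc3c(N)nc(F)nc3n2CC2CCC2)cc(OC)c1OC` gives 40700 nM
- compound 3 `C=CCCn1c(Cc2cc(OC)c(OC)c(OC)c2)nc2c(N)nc(F)nc21` gives 33100 nM

Compound 1 has the highest of the three numbers in this assay, but its nearest neighbour is compound 2, which lies within the scatter of it, and compound 3, the furthest, is also within the scatter. On these numbers, then, the three compounds cannot be separated from one another.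

Compound 4 `COc1cc(Cc2nc3c(N)ncnc3n2C)cc(OC)c1OC` differs from compound 1 in one place: hydrogen in place of but-1-en-1-yl on a saturated chain carbon bound to an aromatic nitrogen. Within the data shown here, the only measured step that touches the same place is the one from compound 2 to compound 3, where a 1.2-fold lower number from compound 2 to compound 3 (0.09 log units; within the scatter). That step swapped one group on the saturated chain carbon bound to the aromatic nitrogen for another and left the number essentially where it was, which suggests that this position tolerates change without much movement in this assay. The change from compound 1 to compound 4 is larger in kind, since a four-carbon unsaturated piece leaves and only a hydrogen enters, so a somewhat wider range is warranted, but no step beyond the scatter is expected in either direction.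

Compound 4 is therefore estimated at 70000 nM in this assay, with a range from 25000 nM to 200000 nM, which corresponds to an expected step of a 1.1-fold higher number from compound 1 to compound 4 (0.03 log units; within the scatter).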

Compound 4, half-maximal inhibitory concentration: 70800 nM
For compound 4 the middle estimate is 1.0-fold (0.00 log units) below the measured one; the measured number falls inside the stated range.
By their numbers in this assay, from the lowest: compounds 3, 2, 1 and 4 (each within the scatter of the next, the first and the last beyond it).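

In this assay, the earlier step at this place only exchanged one carbon group for another, a 1.2-fold lower number from compound 2 to compound 3 (0.09 log units; within the scatter), whereas here the but-1-en-1-yl group, with its 4 carbons and its double bond, gives way to hydrogen, which cuts the pent-2-en-1-yl chain back to methyl, and the result is a 1.1-fold higher number from compound 1 to compound 4 (0.04 log units; within the scatter). So, for this pair on this core, neither the four-carbon piece nor its double bond is needed to keep the number where it stands, and a methyl serves as well as the full chain. No evidence is available on why the number stays put.

These compounds leave open whether a group of another kind on the saturated chain carbon bound to an aromatic nitrogen, such as an amine, a carboxylic acid or a much longer chain, would move the number beyond the scatter. They also leave open whether cutting the chain back to methyl would behave the same way on the core of compound 3, which carries a fluorine that the core of compound 1 lacks.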